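A Smaller Tail Group and What It May Cost

The source may hold more compounds than are shown below. What is called first, only, known or untested is meant among the compounds shown, and "the series" means these compounds.

Of the compounds shown here, three built on one shared core have been measured in a functional assay for agonist activity at G protein-coupled receptor 88 (Homo sapiens), read by HTRF and cAMP accumulation; a higher number here means that more compound is needed for the effect, a lower number that less compound is needed. Going by the values given here, compound 1 `Cc1cccc(-c2ccc(N(C[C@@H](N)CC(C)C)C(=O)[C@@H]3C[C@H]3c3ccccc3)cc2)c1` gives 1200 nM, and compound 2 `CC(C)C[C@H](N)CN(C(=O)[C@@H]1C[C@H]1c1ccccc1)c1ccc(-c2ccc(C#N)cc2)cc1` gives 670 nM; the single change between them, a 1.8-fold lower number from compound 1 to compound 2 (0.25 log units; within the scatter), stays within the scatter. Compound 3 `CC[C@H](C)[C@H](N)CN(C(=O)[C@@H]1C[C@H]1c1ccccc1)c1ccc(-c2ccc(Oc3ccccc3)cc2)cc1` gives 94 nM, the lowest of the three numbers and beyond the scatter from both of the others.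

Compound 4 `CC[C@H](C)[C@H](N)CN(C(=O)[C@@H]1C[C@H]1c1ccccc1)c1ccc(-c2ccc(CN(C)C)cc2)cc1` differs from compound 3 in one place: (dimethylamino)methyl in place of phenoxy on an aromatic carbon. Among the compounds with values here, the only measured step of a related kind, a 1.8-fold lower number from compound 1 to compound 2 (0.25 log units; within the scatter), also exchanged one group for another on an aromatic carbon and barely moved the number. Within the data shown here, the present change is of a different scale, since a whole ring leaves and a short chain enters, and no measured pair shows such an exchange. The number for compound 4 is therefore expected to rise, with wide uncertainty. Compound 4 is estimated at 600 nM, within a range from 150 nM to 3000 nM. That estimate corresponds to an expected step of a 6.4-fold higher number from compound 3 to compound 4 (0.81 log units; beyond the scatter).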

Compound 4, half-maximal effective concentration: 460 nM
For compound 4 the middle estimate is 1.3-fold (0.12 log units) above the measured one; measured number inside the range.
By their numbers in this assay, from the lowest: compound 3; then compounds 4, 2 and 1 (each within the scatter of the next, the first and the last beyond it).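

Going by these compounds alone, on the aromatic carbon para to a large group, this exchange moved the number in this assay clearly, with a 4.9-fold higher number from compound 3 to compound 4 (0.69 log units; beyond the scatter), whereas the only earlier step between measured compounds stayed within the scatter. So the group at this place can matter: replacing phenoxy, with its six-membered aromatic ring, by (dimethylamino)methyl, which has no ring, gives up much of what compound 3 showed, even though the counts of hydrogen-bond donors and acceptors stay the same. No measurement shown here accounts for this step.

As far as these compounds go, one exchange removes the ring and brings in the nitrogen together, so the share of each remains unknown. A benzyl group or a methoxy group at this place could begin to separate the two.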